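From 4-chlorophenyl to butyl near a limit

The source may report more compounds than this note shows. Statements on the series, on what has been measured and on what is new or still open speak of the compounds shown alone.

In a functional assay on K562 cells (Homo sapiens) for inhibition, read by MTT assay, with a stated time of 48 h (a lower number here means a stronger inhibitor, a higher number a weaker inhibitor), compound 1 (`CCCCCn1c(C)cc(NCc2ccc(Cl)cc2)cc1=O`) gives > 300000 nM as a limit, not a number. Compound 3 (`Cc1cc(NCCC(C)C)cc(=O)n1Cc1ccccc1`) gives > 300000 nM as a limit too. Among the measured compounds shown here, compound 2 (`Cc1cc(NCc2ccc(Cl)cc2)cc(=O)n1CCC(C)C`) reads 224000 nM as the only number. The series thus rests largely on the limit of > 300000 nM in this assay, at which 2 of the 3 values shown sit, and little else. Compound 4 (`CCCCCNc1cc(C)n(CCCCC)c(=O)c1`) carries the change butyl in place of 4-chlorophenyl on a saturated chain carbon bound to a nitrogen on an aromatic ring. For the measured compounds named here, the only measured step (an at least 1.3-fold lower number from compound 1 to compound 2 (0.12 log units; that floor lies within the scatter)) concerns another change and stays within the scatter, so none beyond the scatter is expected here. The expected step is a number no higher from compound 1 to compound 4 (the limit leaves the size open) in size. Compound 4 is estimated at 300000 nM with 150000 nM to 600000 nM as its expected span.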

Compound 4, half-maximal inhibitory concentration: 115000 nM
Compound 4: middle estimate off by 2.6-fold (0.42 log units), on the high side; measured number outside the range, below it.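

Butyl in place of 4-chlorophenyl on a saturated chain carbon bound to a nitrogen on an aromatic ring lowers the number in this assay (an at least 2.6-fold lower number from compound 1 to compound 4 (0.41 log units; beyond the scatter)). This is the first listed step to lie beyond the scatter, and it shows that a reading at this position does not depend on keeping the six-membered aromatic ring. As far as these compounds go, its true size stays open, as the step is only a floor set by the limit of compound 1.

From the compounds shown here alone, whether a cyclohexyl ring, a shorter propyl chain or a carboxylic acid in place of butyl would lower the number further remains open.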